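The source may hold more compounds than are shown below. What is called first, only, known or untested is meant among the compounds shown, and "the series" means these compounds.

Measured compounds:
compound 1, `CCCn1nc(C)c2c(C)cc(=O)oc21`, with 54.3 mg/kg
compound 2, `CCN(CC)CCn1nc2oc(=O)cc(C)c2c1C`, with 100 mg/kg
compound 3, `CCCn1nc2oc(=O)cc(C)c2c1C`, with 72.6 mg/kg

All three were tested in a functional assay on the whole organism with Mus musculus as the target, in the writhing test; a higher number here means that more compound is needed for the effect, a lower number that less compound is needed. Compound 1 shows the smallest of the three numbers, yet compound 3 lies a gap within the scatter away, and compound 2 lies further off but still within the scatter, so on these numbers the three compounds cannot be told apart. Among the compounds with values here, the only step between measured compounds that differ in one place is a 1.4-fold lower number from compound 2 to compound 3 (0.14 log units; within the scatter), a change on the chain carried by the aromatic nitrogen that leaves the read-out essentially where it was.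

Compound 4, `Cc1cc(=O)oc2c1c(C)nn2C`, differs from compound 1 by hydrogen in place of ethyl on a saturated chain carbon bound to an aromatic nitrogen. Within the data shown here, no measured pair shortens this chain in the same way, so no direct precedent exists. The nearest comparison is a 1.4-fold lower number from compound 2 to compound 3 (0.14 log units; within the scatter), which also reworks the chain on that nitrogen without moving the number beyond the scatter. On that basis the expected step of a 1.1-fold higher number from compound 1 to compound 4 (0.03 log units; within the scatter) is small and in no clear direction. Compound 4 is therefore estimated to give 58 mg/kg in this assay, with an expected range from 28 mg/kg to 120 mg/kg.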

Compound 4, dose for half-maximal effect: 11.6 mg/kg
Estimate against measurement, compound 4: 5.0-fold (0.70 log units) above, outside the stated range (below it).
By their numbers in this assay, from the lowest: compound 4; then compounds 1, 3 and 2 (each within the scatter of the next).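

In this assay, within the data shown here, the group on the aromatic nitrogen proves able to move the read-out: a 4.7-fold lower number from compound 1 to compound 4 (0.67 log units; beyond the scatter) is a step beyond the scatter, whereas the only earlier step at a chain on that nitrogen, a 1.4-fold lower number from compound 2 to compound 3 (0.14 log units; within the scatter), stayed within it. Among these compounds, the new step is hydrogen in place of ethyl on a saturated chain carbon bound to an aromatic nitrogen, which can equally be read as propyl to methyl, and in this comparison the shorter group is the one that needs less compound for the effect. The earlier step came from a different change on a differently arranged core, so the two show what each change did on its own core and give no general rule for this position, and no evidence is available on why the number falls here.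

With only propyl and methyl compared on the core of compound 1, the compounds shown leave open whether the number follows chain length step by step, as an ethyl or a butyl chain at this nitrogen would show. They also leave open how a chain ending in an amine or a carboxylic acid would fare on this core, and whether the same shortening would give a similar step on the core of compound 3.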